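Taking one methoxy off compound 1: what to expect

The source may hold more compounds than are shown below. What is called first, only, known or untested is meant among the compounds shown, and "the series" means these compounds.

Readings in a functional assay on HL-60 cells (Homo sapiens) for inhibition, read by MTT assay, with a stated time of 72 h (on this read-out higher numbers stand for weaker inhibition and lower numbers for stronger inhibition), so far:
compound 1 `COc1ccc(-c2nc(C)oc2C(=O)N2CCN(c3cccc(Cl)c3)CC2)cc1OC` reads "not active" (no number reported)
compound 2 `COc1cc(OC)cc(N2CCN(C(=O)c3onc(C)c3-c3ccc(F)cc3)CC2)c1` reads 475 nM
compound 3 `CCc1nc(-c2ccc(OC)c(OC)c2)c(C(=O)N2CCN(c3cccc(Cl)c3)CC2)o1` reads "not active" (no number reported)

Compound 1 has no single number. Within the data shown here, it shares that position with compound 3, and compound 2 is the only compound here with a measured number. The next compound to be measured is compound 4 `COc1cccc(-c2nc(C)oc2C(=O)N2CCN(c3cccc(Cl)c3)CC2)c1`, which has hydrogen in place of methoxy on an aromatic carbon and so takes 3,4-dimethoxyphenyl to 3-methoxyphenyl. The place of the change is ortho to a methoxy group and para to a large group. Among the measured compounds shown here, no measured pair shows what this change does in this assay, so any step size is an expectation only. A modest step at most is expected, toward stronger inhibition if there is any step, and compound 4 may well give no number. This expectation rests on compound 1 at "not active" (no number reported) and compound 3 at "not active" (no number reported) as the closest measured compounds. If a number is reported, the estimated value for compound 4 is 5000 nM with an expected range from 800 nM to 30000 nM around it.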

Compound 4, half-maximal inhibitory concentration: "not active" (no number reported)
The entry for compound 4 holds no number; the estimate stays without a comparison.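

In this assay, among these compounds, compound 1 ("not active" (no number reported)) and compound 4 ("not active" (no number reported)) give no pair of numbers, so no step can be read. No evidence bears on this result. The compounds shown leave open what going from 3,4-dimethoxyphenyl to 3-methoxyphenyl does to inhibition.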